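Swapping methyl for methoxy in compound 3

The source may hold more compounds than are shown below. What is called first, only, known or untested is meant among the compounds shown, and "the series" means these compounds.

Compound 3 (`Cc1ccc(S(=O)(=O)Oc2ccccc2/C=C(\C#N)C(=O)Nc2nnc(Cc3ccccc3)s2)cc1`) gives 16% in a functional assay on HL-60 cells (Homo sapiens) for inhibition, read by CCK-8 assay, with a stated time of 48 h, tested at 20 uM (a higher number here means more inhibition of growth at the concentration tested, a lower number less inhibition of growth), and is the lowest of the three measured compounds. Two relatives stand higher, beyond the usual scatter: compound 1 (`COc1ccc(S(=O)(=O)Oc2ccccc2/C=C(\C#N)C(=O)Nc2nnc(-c3cccs3)s2)cc1`) gives 67% and compound 2 (`COc1ccc(S(=O)(=O)Oc2ccccc2/C=C(\C#N)C(=O)Nc2nnc(Cc3cccc4ccccc34)s2)cc1`) gives 98% under the same conditions.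

Compound 4 (`COc1ccc(S(=O)(=O)Oc2ccccc2/C=C(\C#N)C(=O)Nc2nnc(Cc3ccccc3)s2)cc1`) differs from compound 3 in one place (methoxy in place of methyl on an aromatic carbon), where methoxy replaces methyl on an aromatic carbon, para to a large group. This turns 4-methylphenyl into 4-methoxyphenyl.

Going by the values given here, no measured step covers this change directly. Among the compounds with values here, the only step available is a number 31 percentage points higher from compound 1 to compound 2 (beyond the scatter) when (naphthalen-1-yl)methyl replaces thiophen-2-yl on an aromatic carbon. That step is large, but it lies elsewhere in the molecule and says nothing direct about methyl and methoxy. The only hint of direction is that compound 1 with 67% and compound 2 with 98% both carry 4-methoxyphenyl, whereas compound 3, which carries 4-methylphenyl, gives 16%. Both of those relatives stand higher despite differing from compound 3 at that other place too.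

A modest upward move is therefore expected, estimated as a number 14 percentage points higher from compound 3 to compound 4 (beyond the scatter) with wide uncertainty. Compound 4 is estimated at 30% with an expected range from 10% to 65% of growth inhibition.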

Compound 4, percent growth inhibition at one concentration: 100%
Compound 4: the middle estimate sits 70 percentage points below what was measured; measured number above the stated range.
By their numbers in this assay, from the lowest: compound 3; then compound 1; then compounds 2 and 4 (each within the scatter of the next).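

In this assay, going by these compounds alone, methoxy in place of methyl on the aromatic carbon gives a number 84 percentage points higher from compound 3 to compound 4 (beyond the scatter), so this single change has a large effect on its own, whereas the earlier compounds differed from compound 3 at the other end of the molecule as well. With 4-methoxyphenyl held fixed, phenyl in place of naphthalen-1-yl gives a number 2 percentage points higher from compound 2 to compound 4 (within the scatter), which leaves no order between those two compounds, while benzyl in place of thiophen-2-yl gives a number 33 percentage points higher from compound 1 to compound 4 (beyond the scatter), so that end of the molecule still matters. The data shown offer no explanation for the jump between methyl and methoxy.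

The compounds shown leave open what a hydroxyl group, a fluorine atom or a dimethylamino group on the same aromatic carbon would do, and whether swapping methyl for methoxy has an equally large effect when thiophen-2-yl or (naphthalen-1-yl)methyl sits at the other end. A read-out at one concentration also leaves open how compound 2 and compound 4 would compare at lower concentrations.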